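The source may report more compounds than this note shows. Statements on the series, on what has been measured and on what is new or still open speak of the compounds shown alone.

Measured compounds:
Compound 1, `CCCCCn1c(N)nc2ccccc21`: 3230 nM
Compound 2, `CCCCCn1c(N)nc2ccncc21`: "not active" (no number reported)
Compound 3, `CCCCCn1c(N)nc2cc(C)ccc21`: 4570 nM

All three were tested in an assay on HEK293 cells for agonist activity at Toll-like receptor 8 (Homo sapiens), read by reporter gene assay; a lower number here means that less compound is needed, a higher number that more compound is needed for the effect. Compound 1 carries a pentyl chain on its shared core and gives 3230 nM. Compound 3, which differs from it by a methyl group on an aromatic carbon, gives 4570 nM; the step of a 1.4-fold higher number from compound 1 to compound 3 (0.15 log units; within the scatter) lies within the scatter, so the two compounds cannot be told apart on these numbers. Compound 2, in which one ring carbon is replaced by a nitrogen, was reported in this assay as "not active" (no number reported), with no number given, which leaves compound 1 with the lower of the two numbers available, though its nearest neighbour sits within the scatter.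

Compound 4, `CCCCCn1c(N)nc2c(O)cccc21`, has not yet been measured in this assay. It differs from compound 1 as follows: hydroxy in place of hydrogen on an aromatic carbon. For the measured compounds named here, no measured step introduces a hydroxy group, so the only step that bears on the change is the methyl substitution from compound 1 to compound 3, which stayed within the scatter. On that basis a step of a 1.5-fold higher number from compound 1 to compound 4 (0.19 log units; within the scatter) is expected for compound 4, with no change beyond the scatter foreseen. Compound 4 is therefore estimated at 5000 nM, within a range from 1500 nM to 20000 nM.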

Compound 4, half-maximal effective concentration: 5010 nM
Compound 4: middle estimate off by 1.0-fold (0.00 log units), on the low side; low and high end bracket the measured number.
By their numbers in this assay, from the lowest: compounds 1, 3 and 4 (each within the scatter of the next).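

In this assay, placing hydroxy on this aromatic carbon, ortho to a fused ring and meta to a fused ring, gives a 1.6-fold higher number from compound 1 to compound 4 (0.19 log units; within the scatter), so this change cannot be told apart from no change at all. Until now, the only numbered substitution on an aromatic carbon was the methyl group, with a 1.4-fold higher number from compound 1 to compound 3 (0.15 log units; within the scatter); the hydroxy step shows that a group with a hydrogen-bond donor and a hydrogen-bond acceptor, entering at its own position on the ring, also stays within the scatter. No available evidence bears on this result, so the numbers record the outcome without accounting for it.

The compounds shown leave open how an amine, a methoxy group or a carboxylic acid would read on this same aromatic carbon, and whether hydroxy on another carbon of that ring would stay within the scatter as it does here. Every compound shown carries the pentyl chain, so what a longer chain would do alongside the hydroxy group also remains open.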